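Swapping Fluoro for Bromo on an Active Sulfone

The source may hold more compounds than are shown below. What is called first, only, known or untested is meant among the compounds shown, and "the series" means these compounds.

Compound 1 `COc1cc(OC)c(/C=C/S(=O)(=O)Cc2ccc(F)c(N)c2)c(OC)c1`: 2500 nM
Compound 2 `COc1ccc(/C=C/S(=O)(=O)Cc2ccc(OC)c(N)c2)c(OC)c1`: 500 nM

For the measured compounds named here, both compounds have been tested in a functional assay on K562 cells (Homo sapiens) for cytotoxicity, read by trypan blue exclusion, with a stated time of 96 h (a higher number here means a weaker inhibitor, a lower number a stronger inhibitor), where compound 1 gives 2500 nM. That is the higher of the two numbers, so compound 1 is the weaker inhibitor of this pair. Compound 2, at 500 nM, lies lower by more than the usual scatter of repeated measurements. However, the two differ in more than one place, so their gap says nothing about a single change.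

The next compound, compound 3 `COc1cc(OC)c(/C=C/S(=O)(=O)Cc2ccc(Br)c(N)c2)c(OC)c1`, is compound 1 with one substituent exchanged: bromo in place of fluoro on an aromatic carbon. The change sits ortho to an amino group and para to a large group, turning 3-amino-4-fluorophenyl into 3-amino-4-bromophenyl. Going by the values given here, no measured pair shows what this exchange does, so the expectation is cautious: no shift beyond the scatter, with only a slight lean towards a lower number. The expected change is a 1.3-fold lower number from compound 1 to compound 3 (0.10 log units; within the scatter). Compound 3 is estimated at 2000 nM, with an expected range from 600 nM to 6000 nM.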

Compound 3, half-maximal inhibitory concentration: 750 nM
For compound 3 the middle estimate is 2.7-fold (0.43 log units) above the measured one; measured number inside the range.
By their numbers in this assay, from the lowest: compounds 2 and 3 (each within the scatter of the next); then compound 1.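

For the compounds shown here, this is the first pair here that differs in only one place, so a single exchange can now be read. In this assay, bromo in place of fluoro, on the aromatic carbon ortho to the amino group and para to a large group, gives a 3.3-fold lower number from compound 1 to compound 3 (0.52 log units; beyond the scatter), so this position is not indifferent to which of these two halogens it carries, even though the rest of the core of compound 1 stays the same and no hydrogen-bond donor or acceptor enters or leaves. Nothing available here speaks to the cause of this shift.

On these data alone, with only fluoro and bromo compared at this position, it remains open whether other groups there, such as chloro, iodo, methyl or a nitrile, would continue in the same direction or break from it. As far as these compounds go, it is also open whether the same exchange would give a step of similar size on a different core, such as the core of compound 2, or whether the step belongs to the core of compound 1 alone.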